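The source may hold more compounds than are shown below. What is called first, only, known or untested is meant among the compounds shown, and "the series" means these compounds.

Measured so far in a functional assay on HCT-116 cells (Homo sapiens) for antiproliferative activity, read by MTT assay, with a stated time of 72 h; a higher number here means a weaker inhibitor, a lower number a stronger inhibitor:

- compound 1 `C=CC(=O)Nc1nc(-c2ccc(C(F)(F)F)cc2)cs1`: 4000 nM
- compound 2 `C=CC(=O)N(Cc1cc(C)no1)c1nc(-c2ccccc2)cs1`: > 30000 nM (a limit, not a number)

Compound 2 stands only at a limit of this assay, > 30000 nM.

Compound 3 `C=CC(=O)N(Cc1cc(C)no1)c1nc(-c2ccc(C(F)(F)F)cc2)cs1` differs from compound 2 in one place: trifluoromethyl in place of hydrogen on an aromatic carbon, para to a large group (trifluoromethyl in place of hydrogen on an aromatic carbon).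

For the measured compounds named here, no measured pair isolates this change, so any expectation rests on thin ground. Going by the values given here, compound 1 also carries the trifluoromethyl group, and in this assay compound 1 gives 4000 nM, the only true number available. On that basis, a moderate gain in potency is expected in this assay, meaning a lower number, though the result may well remain at the limit of the assay. The expected change is an at least 2.5-fold lower number from compound 2 to compound 3 (0.39 log units; beyond the scatter).

For compound 3 the estimated value is 12000 nM, with an expected range from 4000 nM to 30000 nM.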

Compound 3, half-maximal inhibitory concentration: 19700 nM
For compound 3 the middle estimate is 1.6-fold (0.22 log units) below the measured one, within the range that was stated.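

In this assay, for the compounds shown here, compound 3 gives 19700 nM, the first true number for a compound with (3-methyl-1,2-oxazol-5-yl)methyl on the amide-type nitrogen. Trifluoromethyl in place of hydrogen on the aromatic carbon, para to a large group, gives an at least 1.5-fold lower number from compound 2 to compound 3 (0.18 log units; that floor lies within the scatter), and the true size of this gain stays unknown because the step starts from a limit, not a number: the limit of > 30000 nM in this assay, at which 1 of the 3 values shown sits. With trifluoromethyl held constant, the substituent on the nitrogen can now be read directly, and replacing the amide hydrogen with (3-methyl-1,2-oxazol-5-yl)methyl gives a 4.9-fold higher number from compound 1 to compound 3 (0.69 log units; beyond the scatter), so that change costs potency beyond the scatter in this pair.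

Open, going by these compounds, is whether a chlorine atom or a methoxy group at the same aromatic carbon would give a similar step, and whether trifluoromethyl itself matters beyond the scatter once a parent with a true number is available. Also open, on these data alone, is whether a smaller group on the nitrogen, such as methyl, or a longer chain carrying an amine, would stay closer to the free amide.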